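Oxadiazole-thione series: pyridin-2-yl piperazine analogue

A few compounds are considered here, and "the series" means these few. Any claim that something is new, unique, unknown or untested is made for them only; others in the source may bear on it.

Measured so far:
Compound 1, `Cc1ccc(N2CCN(Cn3nc(-c4ccc5c(c4)OCCO5)oc3=S)CC2)c(C)c1`: 28300 nM
Compound 2, `S=c1oc(-c2ccc3c(c2)OCCO3)nn1CN1CCN(c2ccc(Cl)cc2)CC1`: > 50000 nM

Both compounds were read in a functional assay on BGC-823 cells (Homo sapiens) for antiproliferative activity, read by MTT assay, with a stated time of 48 h; a lower number here means a stronger inhibitor, a higher number a weaker inhibitor. Compound 1 gives 28300 nM in this assay. Compound 2 stands only at a limit of this assay, with no number: compound 2 gives > 50000 nM. Within the data shown here, the one measured step, an at least 1.7-fold higher number from compound 1 to compound 2 (0.24 log units; that floor lies within the scatter), runs toward that limit; the limit of > 50000 nM in this assay, at which 1 of the 2 values shown sits, is all that is known of where compound 2 sits.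

Compound 3, `S=c1oc(-c2ccc3c(c2)OCCO3)nn1CN1CCN(c2ccccn2)CC1`, differs from compound 2 by pyridin-2-yl in place of 4-chlorophenyl on an amine nitrogen in a ring. Among the measured compounds shown here, no measured step covers an exchange of this kind, so the only guide is that compound 2 already sits at the limit. A step of no size beyond the scatter is therefore expected, a number no higher from compound 2 to compound 3 (the limit leaves the size open), and compound 3 is expected to give about 50000 nM in this assay, within 20000 nM to 120000 nM, most likely again reported only as a limit.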

Compound 3, half-maximal inhibitory concentration: 25900 nM
The estimate for compound 3 lay 1.9-fold (0.29 log units) above the measured number; the range from low to high includes it.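

Pyridin-2-yl on an amine nitrogen in a ring gives a measured number in this assay and, against 2,4-dimethylphenyl, the exchange reads a 1.1-fold lower number from compound 1 to compound 3 (0.04 log units; within the scatter) so these two groups cannot be told apart here. Against 4-chlorophenyl the exchange reads an at least 1.9-fold lower number from compound 2 to compound 3 (0.28 log units; that floor lies within the scatter) so the three aromatic rings tried at this position show no separation beyond the scatter. Compound 2 remains a limit and not a number: the limit of > 50000 nM in this assay, at which 1 of the 3 values shown sits.

On these data alone, the true size of the step to compound 3 stays unknown while compound 2 has no number. Also open, as far as these compounds go, is whether pyridin-3-yl, pyridin-4-yl or a non-aromatic group such as cyclohexyl on this nitrogen would shift the number beyond the scatter.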